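Swapping a hydroxyphenyl arm for pyridine on a hydrazone

This account rests on a few compounds, and the source may have more. Where it says the series, first, only, none or still open, it means among the compounds named here.

Of the compounds shown here, two sharing one core have been measured in a functional assay on PC-3 cells (Homo sapiens) for inhibition; on this read-out higher numbers stand for weaker inhibition and lower numbers for stronger inhibition. Compound 1, `Cc1c(C(=O)N/N=C\c2ccc(O)cc2)oc2cccc(O)c12`, carries a 4-hydroxyphenyl on a carbon with a double bond to nitrogen, and in this assay compound 1 gives 21700 nM. Compound 2, `Cc1c(C(=O)N/N=C\c2cc(F)ccc2O)oc2cccc(O)c12`, carries a 5-fluoro-2-hydroxyphenyl at that place instead, and compound 2 gives 3170 nM. That one change brought a 6.8-fold lower number from compound 1 to compound 2 (0.84 log units; beyond the scatter), so compound 2 holds the lowest number of the two, with compound 1 the nearest neighbour.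

Compound 3, `Cc1c(C(=O)N/N=C\c2ccccn2)oc2cccc(O)c12`, is not yet measured. Compared with compound 2 the change is pyridin-2-yl in place of 5-fluoro-2-hydroxyphenyl on a carbon with a double bond to nitrogen. Among the compounds with values here, the only step available, the one from compound 1 to compound 2, shows that this arm matters and that the 5-fluoro-2-hydroxyphenyl form gave the stronger inhibition. Compound 3 gives up that group and its hydrogen-bond donor for a pyridin-2-yl, so a return toward a higher number is expected, though the size is uncertain, and the expected step is a 2.8-fold higher number from compound 2 to compound 3 (0.45 log units; beyond the scatter). The estimate for compound 3 in this assay is 9000 nM, with a range from 2000 nM to 40000 nM.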

Compound 3, half-maximal inhibitory concentration: >= 40000 nM
Compound 3 gave a limit, no number; the forecaster's own chance of this, stated with the estimate: 12%; at least 4.4-fold (0.64 log units) between middle value and limit.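

In this assay compound 3 reaches a limit of the assay, not a number: the limit of >= 40000 nM in this assay, at which 1 of the 3 values shown sits.

The earlier compounds shown here showed only that this arm, on a carbon with a double bond to nitrogen, can shift the read-out between two measurable values, whereas pyridin-2-yl in place of 5-fluoro-2-hydroxyphenyl brings an at least 12-fold higher number from compound 2 to compound 3 (1.10 log units; beyond the scatter), which takes the read-out out of the measurable range and shows that most of the inhibition seen with compound 2 depends on what sits at this place. Set against the 4-hydroxyphenyl arm, the same group gives an at least 1.8-fold higher number from compound 1 to compound 3 (0.26 log units; that floor lies within the scatter), so the data do not settle how compound 3 stands relative to compound 1, only that the pyridin-2-yl arm does not recover the stronger inhibition of compound 2.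

The change removes a hydrogen-bond donor, drops the fluorine and brings in a ring nitrogen all at once, so the compounds shown cannot say which of these accounts for the step. A plain phenyl arm, or a 2-hydroxyphenyl arm without fluorine, would pull these apart, and a 2-aminophenyl arm would test whether another donor can stand in for the hydroxyl.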